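This account rests on a few compounds, and the source may have more. Where it says the series, first, only, none or still open, it means among the compounds named here.

Compound 2 `c1ccc(-c2nc3ccn(CC4CCCCC4)cc-3n2)cc1` gives > 100000 nM in an ADME assay on MDBK cells (Bos taurus) for cytotoxicity (on this read-out higher numbers stand for lower toxicity in this test and lower numbers for higher toxicity in this test), which is a limit of the assay and not a number. Compound 1 `N#Cc1ccccc1Cn1ccc2nc(-c3ccccc3)nc-2c1` gives > 100000 nM, also a limit. Within the data shown here, the series so far stands entirely at one end of the range: the limit of > 100000 nM in this assay, at which 2 of the 2 values shown sit.

Compound 3 `C(=C/c1ccccc1)\Cn1ccc2nc(-c3ccccc3)nc-2c1` carries the next change on the shared core: 2-phenylethenyl in place of cyclohexyl on a saturated chain carbon bound to an aromatic nitrogen. In words, 2-phenylethenyl replaces cyclohexyl on a saturated chain carbon bound to an aromatic nitrogen.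

Among the measured compounds shown here, only one measured step bears on this place, a step that the two limits leave unreadable from compound 1 to compound 2, and it has no readable size. For the measured compounds named here, with that step as the sole guide, no step beyond the scatter is expected in this assay, and no direction can be favoured. The expected step is a number no higher from compound 2 to compound 3 (the limit leaves the size open). For compound 3 the estimated value is 100000 nM, with an expected range from 40000 nM to 200000 nM.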

Compound 3, half-maximal cytotoxic concentration: 78000 nM
For compound 3 the middle estimate is 1.3-fold (0.11 log units) above the measured one, within the range that was stated.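

Among these compounds, compound 3 gives the first value in this assay at this position that is a number and not a limit, with 2-phenylethenyl on a saturated chain carbon bound to an aromatic nitrogen. The two replacements read as an at least 1.2-fold lower number from compound 2 to compound 3 (0.10 log units; that floor lies within the scatter) and an at least 1.2-fold lower number from compound 1 to compound 3 (0.10 log units; that floor lies within the scatter), so neither is shown to move the read-out beyond the scatter, and their true sizes stay open. The series therefore still stands largely at one end of the range: the limit of > 100000 nM in this assay, at which 2 of the 3 values shown sit.

Open, going by these compounds, is whether an amine or a carboxylic acid in this place would give a clearly lower number. Also open, on these data alone, is whether 2-phenylethyl, which lacks the double bond outside the aromatic ring, would give a number or a limit in this assay.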